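The source may report more compounds than this note shows. Statements on the series, on what has been measured and on what is new or still open speak of the compounds shown alone.

In a functional assay on K562 cells (Homo sapiens) for inhibition, read by trypan blue exclusion, with a stated time of 24 h, tested at 10 uM (a higher number here means more inhibition of growth at the concentration tested, a lower number less inhibition of growth), compound 1 `Cc1ccccc1OCC(=O)Nc1ccccc1C(N)=O` gives 19.7%. Compound 3 `Cc1ccc(NC(=O)COc2ccccc2C)c(C(N)=O)c1` differs from compound 1 by one change, (methyl in place of hydrogen on an aromatic carbon), and in this assay compound 3 gives 45.6%. Among the compounds with values here, the step of a number 25.9 percentage points higher from compound 1 to compound 3 (beyond the scatter) is the one measured step in this set.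

Compound 2 `NC(=O)c1ccccc1NC(=O)COc1cccc(Cl)c1Cl` shares the core of compound 1, but the difference between the two cores is not broken down here. In this assay compound 2 reports only a limit, < 10%. This is the limit at which (the limit of < 10% in this assay, at which 1 of the 3 values shown sits), so no number is known for compound 2 at the tested concentration.

Compound 4 `Cc1ccc(NC(=O)COc2cccc(Cl)c2Cl)c(C(N)=O)c1` has not yet been measured. It stands to compound 2 as compound 3 stands to compound 1: the change is methyl in place of hydrogen on an aromatic carbon. The place of the entering methyl is described in the same words for both pairs, so the change is the same one made from compound 1 to compound 3.

Because a number 25.9 percentage points higher from compound 1 to compound 3 (beyond the scatter) raised growth inhibition by a modest but real amount, the step from compound 2 to compound 4 is expected to be of a similar size, a number at least 15 percentage points higher from compound 2 to compound 4 (beyond the scatter), though its starting point is only a limit and the estimate is correspondingly uncertain. Compound 4 is therefore expected to give 25%, with a likely range from 8% to 45%.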

Compound 4, percent growth inhibition at one concentration: 30.8%
Compound 4: the middle estimate sits 5.8 percentage points below what was measured; the range from low to high includes it.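

In this assay, methyl in place of hydrogen on an aromatic carbon, meta to a carbamoyl group, again comes with more growth inhibition on the second core, giving a number at least 20.8 percentage points higher from compound 2 to compound 4 (beyond the scatter). The change therefore points the same way on both cores shown, but two cores do not establish a rule for the series, and the sizes of the two steps cannot be matched: the same change on two cores in this assay, a number 25.9 percentage points higher (beyond the scatter) from compound 1 to compound 3 and a number at least 20.8 percentage points higher (beyond the scatter) from compound 2 to compound 4; the limit leaves it open whether they differ. Compound 2 gives < 10%, which is a limit and not a number.

The compounds shown leave open whether an ethyl group, a methoxy group or an amine in the same place on the aromatic ring would go with a similar step. They also leave open whether the methyl step would hold on a core carrying a single chlorine or a nitrile where compound 1 and compound 2 differ from each other.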